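Back from a Fluorinated Ring to an Aryl Amide

This account rests on a few compounds, and the source may have more. Where it says the series, first, only, none or still open, it means among the compounds named here.

Compound 1, `O=C(c1ccc(Cl)cc1)N1CC(c2nc(-c3cccc(F)c3)no2)C1`, gives 2500 nM in an assay on HEK293 cells for positive allosteric modulation of metabotropic glutamate receptor 5 (Homo sapiens), read by FLIPR; a lower number here means that less compound is needed, a higher number that more compound is needed for the effect.
Compound 2, `O=C(C1CCC(F)(F)CC1)N1CC(c2nc(-c3cccc(F)c3)no2)C1`, gives 520 nM in this assay.

Among the compounds with values here, compound 2 has the lowest of the two numbers; its only neighbour is compound 1, separated by the step of a 4.8-fold lower number from compound 1 to compound 2 (0.68 log units; beyond the scatter). Compound 3, `Cc1ccc(C(=O)N2CC(c3nc(-c4cccc(F)c4)no3)C2)cc1`, is not yet measured and differs from compound 2 in one place: 4-methylphenyl in place of 4,4-difluorocyclohexyl on a carbonyl carbon. Within the data shown here, the one measured step that bears on this change is a 4.8-fold lower number from compound 1 to compound 2 (0.68 log units; beyond the scatter), which traded an aromatic ring for a non-aromatic one. Compound 3 brings an aromatic ring back, so a rise of about that size is expected in this assay, namely a 3.8-fold higher number from compound 2 to compound 3 (0.59 log units; beyond the scatter). Compound 3 is therefore estimated at 2000 nM, with a range from 700 nM to 6000 nM.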

Compound 3, half-maximal effective concentration: 6800 nM
Beside the measured number, compound 3's estimate is 3.4-fold (0.53 log units) below it; measured number above the stated range.
By their numbers in this assay, from the lowest: compound 2; then compound 1; then compound 3.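

Replacing the ring on the carbonyl carbon is not a fixed penalty for aromaticity, since the change gives a 13-fold higher number from compound 2 to compound 3 (1.12 log units; beyond the scatter) in this assay, while the substituent on the aromatic ring also counts. Methyl in place of chloro on an aromatic carbon gives a 2.7-fold higher number from compound 1 to compound 3 (0.43 log units; beyond the scatter), so the two aryl amides do not behave alike. No measured evidence here explains either step. The compounds shown leave open whether the lower number of compound 2 depends on its non-aromatic ring or on its two fluorines, which a plain cyclohexyl would separate. Where an unsubstituted phenyl would fall relative to the two aryl amides also remains open.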